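Chloro added to compound 2: working notes

The compounds below may be only part of what the source reports. "The series", "measured", "known", "first", "only" and "open" are said of these compounds alone.

Measured so far in a functional assay on K562 cells (Homo sapiens) for antiproliferative activity, read by trypan blue exclusion, with a stated time of 48 h, tested at 10 uM; on this read-out lower numbers stand for less inhibition of growth and higher numbers for more inhibition of growth at the one concentration tested
compound 1 `Cc1ccc(NC(=O)/C=C/c2ccccc2)c(C(N)=O)c1` gives 65.4%
compound 2 `NC(=O)c1cc(Br)ccc1NC(=O)/C=C/c1ccccc1` gives 62.4%
compound 3 `Cc1ccc(/C=C/C(=O)Nc2ccc(Cl)cc2C(N)=O)cc1` gives 64%

Compound 2 at 62.4% stands within the scatter of both compound 1 and compound 3, so the three form one level with no order among them. Compound 4 `NC(=O)c1cc(Br)ccc1NC(=O)/C=C/c1cccc(Cl)c1` carries one change relative to compound 2 (chloro in place of hydrogen on an aromatic carbon), chloro in place of hydrogen on an aromatic carbon, meta to a large group, so that phenyl becomes 3-chlorophenyl.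

For the measured compounds named here, the only measured step that bears on this (a number 3 percentage points lower from compound 1 to compound 2 (within the scatter)) is a different change, bromo in place of methyl on an aromatic carbon, so its evidence is indirect. Going by the values given here, no measured pair here shows chloro in place of hydrogen. That step stays within the scatter, so no step beyond the scatter is expected in this assay in either direction. The estimated step is small (a number 0.6 percentage points higher from compound 2 to compound 4 (within the scatter)) and these data do not settle its sign. Compound 4 is expected at 63% within an estimated range of 49% to 77% for a single measurement.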

Compound 4, percent growth inhibition at one concentration: 25.5%
Estimate against measurement, compound 4: 37.5 percentage points above, outside the stated range (below it).
By their numbers in this assay, from the lowest: compound 4; then compounds 2, 3 and 1 (each within the scatter of the next).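

In this assay, for the compounds shown here, phenyl to 3-chlorophenyl gives a number 36.9 percentage points lower from compound 2 to compound 4 (beyond the scatter), the first step that lies beyond the scatter. This position, meta to a large group, is therefore not indifferent to change: a single chlorine atom, with no ring, no hydrogen-bond donor or acceptor and no net charge, removes much of the growth inhibition seen at the one concentration tested, whereas bromo in place of methyl elsewhere on the molecule gives only a number 3 percentage points lower from compound 1 to compound 2 (within the scatter). No measurement at hand bears on why chloro has this effect here.

As far as these compounds go, whether the loss belongs to chloro alone or would follow any group at this position remains open, and a methoxy group, an amine or a carboxylic acid in the same place would separate those two readings. The read-out, taken at a single concentration, also leaves open how far the full concentration response of compound 4 lies from that of compound 2.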